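The source may hold more compounds than are shown below. What is called first, only, known or untested is meant among the compounds shown, and "the series" means these compounds.

Compound 1 (`C=C(Br)C(=O)Nc1ccc(C(=O)/C=C/c2ccccc2)cc1`), compound 2 (`C=C(Br)C(=O)Nc1ccc(C(=O)/C=C/c2ccc(OC)cc2)cc1`) and compound 3 (`C=C(Br)C(=O)Nc1ccc(C(=O)/C=C/c2ccc(N(C)C)cc2)cc1`) all carry the (1-bromoethenyl)carbonyl group. In a functional assay on HeLa cells (Homo sapiens) for antiproliferative activity, with a stated time of 48 h (a lower number here means a stronger inhibitor, a higher number a weaker inhibitor), compound 3 gives 610 nM and lies within the scatter of both others, with compound 1 at 960 nM and compound 2 at 310 nM on the same scale. Compound 4 (`CN(C)c1ccc(/C=C/C(=O)c2ccc(N)cc2)cc1`) has hydrogen in place of (1-bromoethenyl)carbonyl on a nitrogen on an aromatic ring. The measured steps (a 3.1-fold lower number from compound 1 to compound 2 (0.49 log units; beyond the scatter)) and (a 1.6-fold lower number from compound 1 to compound 3 (0.20 log units; within the scatter)) and (a 2.0-fold higher number from compound 2 to compound 3 (0.29 log units; within the scatter)) only exchange groups on an aromatic carbon, so none bears directly on this change. Within the data shown here, no measured compound lacks that group, and compound 3 at 610 nM still holds it, so a step to a higher number well beyond the scatter is expected. The expected step is a 20-fold higher number from compound 3 to compound 4 (1.29 log units; beyond the scatter) in this estimate. Compound 4 is estimated at 12000 nM with 3000 nM to 45000 nM as its range.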

Compound 4, half-maximal inhibitory concentration: 28000 nM
Estimate against measurement, compound 4: 2.3-fold (0.37 log units) below, within the range that was stated.
By their numbers in this assay, from the lowest: compounds 2, 3 and 1 (each within the scatter of the next, the first and the last beyond it); then compound 4.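

Among these compounds, replacing (1-bromoethenyl)carbonyl with hydrogen on the nitrogen gives a 46-fold higher number from compound 3 to compound 4 (1.66 log units; beyond the scatter) in this assay, the first reading of any change at this position. In this one pair, the stronger inhibition goes with the group being present. Nothing measured here explains the size of this step.

From the compounds shown here alone, it remains open whether an acetyl or a plain ethenylcarbonyl on the same nitrogen would keep the number seen for compound 3. Also open, going by these compounds, is whether removing the group costs as much with the methoxy of compound 2 or the unsubstituted ring of compound 1.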